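Amide-Bearing Chains on the Piperidine Scaffold of a Kinase Inhibitor

The source may report more compounds than this note shows. Statements on the series, on what has been measured and on what is new or still open speak of the compounds shown alone.

Measured so far:
compound 1 `Cn1ncc(Cl)c1-c1cc(C(=O)NC2CNCCC2c2ccc(C(F)(F)F)cc2)oc1Cl`: 7.2 nM
compound 2 `Cn1ncc(Cl)c1-c1cc(C(=O)N[C@@H]2CN[C@H](CCCO)C[C@H]2c2ccc(Cl)c(Cl)c2)oc1Cl`: 2.56 nM
compound 3 `CC(=O)NCC[C@@H]1C[C@@H](c2ccc(F)c(F)c2)[C@H](NC(=O)c2cc(-c3c(Cl)cnn3C)c(Cl)o2)CN1`: 2.49 nM

Of the compounds shown here, three have been tested in an assay for inhibition of RAC-alpha serine/threonine-protein kinase (Homo sapiens), read by HTRF, with a stated time of 1 h; a lower number here means a stronger inhibitor, a higher number a weaker inhibitor. Compound 1 gives 7.2 nM, compound 2 gives 2.56 nM, and compound 3 gives 2.49 nM. Compound 2 stands second highest of the three numbers; its value and that of compound 3 lie within the scatter of each other, whereas compound 1 gives a higher number, and that gap lies beyond the scatter.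

Compound 4 `Cn1ncc(Cl)c1-c1cc(C(=O)N[C@@H]2CN[C@H](CC(=O)NC3CC3)C[C@H]2c2ccc(Cl)c(Cl)c2)oc1Cl` has not yet been measured. It differs from compound 2 in a single place: cyclopropylcarbamoyl in place of 2-hydroxyethyl on a saturated chain carbon bound to a saturated ring carbon. Within the data shown here, no pair of measured compounds differing in one place is available, so the size of this step cannot be read from a precedent. Compound 3 also carries an amide-bearing chain on a saturated ring carbon and gives 2.49 nM, which is close to compound 2, so an amide at that part of the molecule appears to be tolerated. Compound 4 is therefore expected to give 3 nM, with a range from 1.2 nM to 8 nM. This estimate means an expected step of a 1.2-fold higher number from compound 2 to compound 4 (0.07 log units; within the scatter), which is not beyond the scatter in either direction.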

Compound 4, half-maximal inhibitory concentration: 3.95 nM
The estimate for compound 4 lay 1.3-fold (0.12 log units) below the measured number; measured number inside the range.
By their numbers in this assay, from the lowest: compounds 3, 2, 4 and 1 (each within the scatter of the next, the first and the last beyond it).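

In this assay, among these compounds, the exchange of 2-hydroxyethyl for cyclopropylcarbamoyl gives a 1.5-fold higher number from compound 2 to compound 4 (0.19 log units; within the scatter) and provides the first direct one-place reading at this position, on a saturated chain carbon bound to a saturated ring carbon. The entering group has more heavy atoms and a three-membered ring of carbon only, with the same count of hydrogen-bond donors and acceptors, yet the two values lie within the scatter of each other. No available evidence bears on why these two groups read alike. On these data alone, it remains open whether a carboxylic acid, an amine or a longer chain at this place would also stay within the scatter of compound 2. The compounds shown also cannot separate the contribution of the cyclopropyl ring from that of the amide, which a simple methyl amide would test.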